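The source may hold more compounds than are shown below. What is called first, only, known or untested is meant among the compounds shown, and "the series" means these compounds.

Measured so far in a functional assay on CHO-K1 cells for antagonist activity at transient receptor potential cation channel subfamily V member 1 (Homo sapiens), read by FLIPR; on this read-out lower numbers stand for stronger inhibition and higher numbers for weaker inhibition:
- compound 1 `Cc1ccc(Nc2nc(C(F)(F)F)ccc2CNC(=O)C(C)c2ccc(NS(C)(=O)=O)c(F)c2)cc1C`: 39.3 nM
- compound 2 `Cc1ccc(Cl)cc1Nc1nc(C(F)(F)F)ccc1CNC(=O)C(C)c1ccc(NS(C)(=O)=O)c(F)c1`: 14 nM
- compound 3 `CC(C(=O)NCc1ccc(C(F)(F)F)nc1N1CCC(=O)CC1)c1ccc(NS(C)(=O)=O)c(F)c1`: 91 nM

Compound 1 stands second highest of the three numbers; compound 2 lies below it by a 2.8-fold lower number from compound 1 to compound 2 (0.45 log units; beyond the scatter) and compound 3 above it by a 2.3-fold higher number from compound 1 to compound 3 (0.36 log units; beyond the scatter), both beyond the scatter.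

Compound 4 `CC(C(=O)NCc1ccc(C(F)(F)F)nc1N1CCN(C)CC1)c1ccc(NS(C)(=O)=O)c(F)c1` has not been measured. Relative to compound 1 it carries 4-methylpiperazin-1-yl in place of (3,4-dimethylphenyl)amino on an aromatic carbon.

Among the measured compounds shown here, the steps that bear on this are those in which the arylamino group at this position is exchanged for a saturated six-membered ring: a 2.3-fold higher number from compound 1 to compound 3 (0.36 log units; beyond the scatter) and a 6.5-fold higher number from compound 2 to compound 3 (0.81 log units; beyond the scatter), each a loss. The 4-methylpiperazin-1-yl of compound 4 is not the 4-oxopiperidin-1-yl of compound 3, so the size is uncertain, but the direction is expected to be the same. For compound 4 a weakening step of a 3.8-fold higher number from compound 1 to compound 4 (0.58 log units; beyond the scatter) is therefore expected, and the value in this assay is estimated at 150 nM, within a range from 50 nM to 500 nM.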

Compound 4, inhibition constant: 146 nM
Estimate against measurement, compound 4: 1.0-fold (0.01 log units) above; the measured number falls inside the stated range.
By their numbers in this assay, from the lowest: compound 2; then compound 1; then compounds 3 and 4 (each within the scatter of the next).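

In this assay the loss on replacing the arylamino group is not tied to 4-oxopiperidin-1-yl, since 4-methylpiperazin-1-yl also weakens the series (a 3.7-fold higher number from compound 1 to compound 4 (0.57 log units; beyond the scatter)), and the step from the chlorinated arylamino compound is large (a 10-fold higher number from compound 2 to compound 4 (1.02 log units; beyond the scatter)). The two saturated rings cannot be told apart (a 1.6-fold higher number from compound 3 to compound 4 (0.21 log units; within the scatter)), so exchanging the ring ketone for an N-methyl amine gives no readable change at this position. Nothing available explains the loss or the likeness of these two rings.

In these compounds, the change from an aromatic to a non-aromatic ring always comes with the loss of the hydrogen-bond donor, so the two changes stay unseparated; a cyclohexylamino group would keep that nitrogen hydrogen on a saturated ring. Going by these compounds, whether morpholin-4-yl or an open-chain dialkylamine would fall with the two saturated rings also remains open.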